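Naphthyl for phenyl on the benzylsulfanyl arm of compound 1

This account rests on a few compounds, and the source may have more. Where it says the series, first, only, none or still open, it means among the compounds named here.

The series shares one core bearing a sulfonylguanidine hydrazone and a benzylsulfanyl arm. Compound 1 `Cc1cc(S(=O)(=O)/N=C(\N)N/N=C/C#Cc2ccccc2)c(SCc2ccccc2)cc1Cl` stands lowest of the three measured compounds in a functional assay on MCF7 cells (Homo sapiens) for antiproliferative activity, read by MTT assay, with a stated time of 72 h (on this read-out lower numbers stand for stronger inhibition and higher numbers for weaker inhibition), where compound 1 gives 24000 nM. Compound 2 `C/C(C#Cc1ccccc1)=N\N/C(N)=N/S(=O)(=O)c1cc(C)c(Cl)cc1SCc1ccccc1` gives 110000 nM, and compound 3 `C/C(C#Cc1ccccc1)=N\N/C(N)=N/S(=O)(=O)c1cc(C)c(Cl)cc1SCc1cccc(Cl)c1` gives 80000 nM. The step of a 4.6-fold higher number from compound 1 to compound 2 (0.66 log units; beyond the scatter) is the only one beyond the scatter; the step of a 1.4-fold lower number from compound 2 to compound 3 (0.14 log units; within the scatter), which puts chloro on the benzylsulfanyl arm, stays within the scatter.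

Compound 4 `Cc1cc(S(=O)(=O)/N=C(\N)N/N=C/C#Cc2ccccc2)c(SCc2cccc3ccccc23)cc1Cl` differs from compound 1 by naphthalen-1-yl in place of phenyl on a saturated chain carbon bound to a sulfur. Going by the values given here, no measured step changes this arm in the same way; the nearest comparison, compound 2 to compound 3, altered the same arm and moved the number little. On that basis compound 4 is expected to stay near compound 1, with a step of no change at the digits printed from compound 1 to compound 4 (within the scatter) that is not expected to exceed the scatter. The estimate for compound 4 in this assay is 24000 nM, with a range from 8000 nM to 70000 nM.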

Compound 4, half-maximal inhibitory concentration: 22000 nM
Beside the measured number, compound 4's estimate is 1.1-fold (0.04 log units) above it; the range from low to high includes it.
By their numbers in this assay, from the lowest: compounds 4 and 1 (each within the scatter of the next); then compounds 3 and 2 (each within the scatter of the next).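

In this assay the arm takes the larger ring system: naphthalen-1-yl in place of phenyl on a saturated chain carbon bound to a sulfur gives a 1.1-fold lower number from compound 1 to compound 4 (0.04 log units; within the scatter) and so adds a second aromatic ring of carbon only with no difference beyond the scatter. Until now, the only change shown on this arm was the small chloro in place of hydrogen (on the compound 2 background), whereas the only step beyond the scatter remains a 4.6-fold higher number from compound 1 to compound 2 (0.66 log units; beyond the scatter), at a different place. Nothing at hand explains why the number holds across this change.

Open, as far as these compounds go, is whether an amine or a carboxylic acid on this ring, or a longer chain on the sulfur in place of benzyl, would move the number. Also open, from the compounds shown here alone, is whether naphthalen-1-yl gives the same result on the compound 2 background.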